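The source may report more compounds than this note shows. Statements on the series, on what has been measured and on what is new or still open speak of the compounds shown alone.

Measured in a functional assay on ACHN cells (Homo sapiens) for inhibition, read by sulforhodamine B assay, with a stated time of 48 h; on this read-out higher numbers stand for weaker inhibition of growth and lower numbers for stronger inhibition of growth:
- compound 1 `Cc1ccc(NC(=O)/C=C/c2ccccc2)c(C(N)=O)c1`: 13500 nM
- compound 2 `NC(=O)c1cc(I)ccc1NC(=O)/C=C/c1ccccc1`: 3700 nM

Compound 2 holds the lower of these two numbers, so it is the stronger growth inhibitor so far. Compound 3 `NC(=O)c1cc(I)ccc1NC(=O)/C=C/c1ccccc1Cl` differs from it by chloro in place of hydrogen on an aromatic carbon, a chloro in place of hydrogen on an aromatic carbon. Among the compounds with values here, the only measured step, a 3.6-fold lower number from compound 1 to compound 2 (0.56 log units; beyond the scatter), was modest and concerned iodo in place of methyl, so it is only a loose guide. A step no larger is therefore expected in this assay, perhaps slightly downward and possibly within the scatter. Compound 3 is estimated at 3000 nM, with an expected range of 1000 nM to 9000 nM. This estimate means an expected 1.2-fold lower number from compound 2 to compound 3 (0.09 log units; within the scatter).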

Compound 3, concentration for 50% growth inhibition: 9860 nM
Beside the measured number, compound 3's estimate is 3.3-fold (0.52 log units) below it; measured number outside the range, above it.
By their numbers in this assay, from the lowest: compound 2; then compounds 3 and 1 (each within the scatter of the next).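

In this assay, changing phenyl to 2-chlorophenyl gave a 2.7-fold higher number from compound 2 to compound 3 (0.43 log units; beyond the scatter), so growth inhibition became weaker by more than the scatter. Within the data shown here, the earlier step concerned a different place, so this is the first sign that the phenyl also affects the number, and that a single added chlorine atom is enough to shift it. Nothing measured here explains this weakening. As far as these compounds go, it remains open how fluoro, methoxy or an amine would fare at this same place, and whether chloro elsewhere on the phenyl would also raise the number.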